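The compounds below may be only part of what the source reports. "The series", "measured", "known", "first", "only" and "open" are said of these compounds alone.

In an ADME assay on microsomes from liver (Homo sapiens) for metabolic stability (on this read-out lower numbers stand for slow clearance and higher numbers for fast clearance), two compounds with the same core have been measured so far. Compound 1 (`Cc1cc(C)c2cc(C(=O)NC3CN(c4cc(Cl)ncc4Cl)C3)ccc2n1`) gives 160 mL/min/kg, and compound 2 (`Cc1cc(C)c2cc(C(=O)NC3CN(c4ccnc(F)c4F)C3)ccc2n1`) gives 129 mL/min/kg. These two numbers lie within the usual scatter of repeated measurements, so compound 2 cannot be ranked apart from compound 1.

Compound 3 (`COc1cc(N2CC(NC(=O)c3ccc4nc(C)cc(C)c4c3)C2)c(Cl)cn1`) keeps the core but has 5-chloro-2-methoxypyridin-4-yl in place of 2,3-difluoropyridin-4-yl on an amine nitrogen in a ring. The counted difference is 5-chloro-2-methoxypyridin-4-yl in place of 2,3-difluoropyridin-4-yl on an amine nitrogen in a ring.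

Going by the values given here, only one measured step bears on this change, as it swaps groups at the same place: a 1.2-fold lower number from compound 1 to compound 2 (0.09 log units; within the scatter). That exchange of one substituted pyridine group for another left the read-out within the scatter. Among the compounds with values here, it is a single step, however, and no compound carrying a methoxy group has been measured, so the evidence is thin. No change beyond the scatter is therefore expected, and the estimated step is a 1.1-fold higher number from compound 2 to compound 3 (0.04 log units; within the scatter).

For compound 3, the estimated clearance is 140 mL/min/kg, with an expected range of 85 mL/min/kg to 220 mL/min/kg.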

Compound 3, clearance: 106 mL/min/kg
For compound 3 the middle estimate is 1.3-fold (0.12 log units) above the measured one, within the range that was stated.
By their numbers in this assay, from the lowest: compounds 3, 2 and 1 (each within the scatter of the next).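

In this assay, going by these compounds alone, the pyridine group on an amine nitrogen in a ring has now been exchanged a second time, and a 1.2-fold lower number from compound 2 to compound 3 (0.09 log units; within the scatter) shows that this exchange, which brings in an oxygen-bearing group for the first time, also stays within the scatter. The narrower exchange of methoxy in place of chloro on an aromatic carbon gives a 1.5-fold lower number from compound 1 to compound 3 (0.18 log units; within the scatter) and also stays within the scatter, so neither a change of one substituent nor a change of the whole substituted pyridine group separates these compounds on this read-out, and compounds 1, 2 and 3 cannot be told apart. No accompanying measurement offers an explanation for this similarity.

On these data alone, it remains open whether an amine or a nitrile on the pyridine, or a phenyl ring in place of the pyridine, would give a step beyond the scatter at this position on the four-membered ring. As far as these compounds go, since all three compounds share the same core and amide, the effect of replacing one of the methyl groups on that core with a carboxylic acid or a longer chain also remains open.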